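Aryl linker variation on the shared core

A few compounds are considered here, and "the series" means these few. Any claim that something is new, unique, unknown or untested is made for them only; others in the source may bear on it.

Compound 1 `Cc1c(Cc2ccccc2S(=O)(=O)c2ccc(Cl)cc2)c2c(n1CC(=O)O)CCNC2=O` carries a (4-chlorophenyl)sulfonyl group on an aromatic carbon, and in a functional assay on CHO.K1 cells for antagonist activity at prostaglandin D2 receptor 2 (Homo sapiens), read by GTPgammaS binding, with a stated time of 1 h (a higher number here means a weaker inhibitor, a lower number a stronger inhibitor), compound 1 gives 8.5 nM. Compound 2 `Cc1c(Cc2ccccc2C(O)c2ccccc2)c2c(n1CC(=O)O)CCNC2=O` replaces that group with hydroxy(phenyl)methyl, and in this assay compound 2 gives 32 nM; the step is a 3.8-fold higher number from compound 1 to compound 2 (0.58 log units; beyond the scatter). Among the two measured values compound 2 therefore stands at the higher, weaker end, its only neighbour being compound 1.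

Compound 3 `Cc1c(Cc2ccccc2Oc2ccccc2)c2c(n1CC(=O)O)CCNC2=O` is the next variation at the same position: phenoxy in place of hydroxy(phenyl)methyl on an aromatic carbon. Among the measured compounds shown here, the only measured step that bears on this position is the one from compound 1 to compound 2, which was modest and moved the number upward when the sulfonyl-linked ring gave way to the hydroxy-bearing carbon link. Phenoxy keeps a single-atom link to the second ring but has no hydrogen-bond donor, so a number between those of compound 1 and compound 2 looks plausible. The step expected in this assay is a 1.6-fold lower number from compound 2 to compound 3 (0.20 log units; within the scatter), a small decrease that may not exceed the scatter. Compound 3 is accordingly estimated at 20 nM, with a range from 6 nM to 65 nM.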

Compound 3, half-maximal inhibitory concentration: 530 nM
The estimate for compound 3 lay 27-fold (1.42 log units) below the measured number, outside the stated range (above it).
By their numbers in this assay, from the lowest: compound 1; then compound 2; then compound 3.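

In this assay, keeping a second aromatic ring at this position does not by itself hold the activity: hydroxy(phenyl)methyl and phenoxy each bring one six-membered aromatic ring of carbon only, yet the exchange gives a 17-fold higher number from compound 2 to compound 3 (1.22 log units; beyond the scatter). That step is large, whereas the earlier 3.8-fold higher number from compound 1 to compound 2 (0.58 log units; beyond the scatter) is modest, so the position tolerates some changes of link far better than others, and compound 3 is the weakest of the three, with a 62-fold higher number from compound 1 to compound 3 (1.79 log units; beyond the scatter). No measured evidence on the compounds explains why the phenoxy link costs so much.

The exchange from compound 2 to compound 3 changes the linking atom and also goes from 1 hydrogen-bond donor to 0 hydrogen-bond donors, so the compounds shown cannot separate these two changes, and benzyl or anilino groups at this position would bear on that question. The step from compound 1 to compound 3 also combines a change of link with the loss of the ring chlorine, leaving open whether a 4-chlorophenoxy group would recover any of the lost activity.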